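Shortening the ether tail from cyclohexyl to ethyl

A few compounds are considered here, and "the series" means these few. Any claim that something is new, unique, unknown or untested is made for them only; others in the source may bear on it.

Measured so far:
compound 2, `[O-][n+]1nc(NCOC2CCCCC2)[n+]([O-])c2ccccc21`: 6670 nM
compound 1, `[O-][n+]1nc(NCOCc2ccc(Cl)cc2)[n+]([O-])c2ccccc21`: 5100 nM

In a functional assay on PC-3 cells (Homo sapiens) for cytotoxicity, read by MTT assay, with a stated time of 72 h (on this read-out higher numbers stand for weaker inhibition and lower numbers for stronger inhibition), compound 2 gives 6670 nM, and compound 1 gives 5100 nM; the two numbers sit within the usual scatter of each other, so neither can be called the stronger. Compound 3, `CCOCNc1n[n+]([O-])c2ccccc2[n+]1[O-]`, carries the change (ethyl in place of cyclohexyl on an oxygen on a saturated carbon). Going by the values given here, no step between measured compounds bears on this change, so the direction is open; a modest move toward weaker inhibition, or none beyond the scatter, is expected in this assay. Compound 3 is estimated at 9000 nM, between 3000 nM and 30000 nM, the expected step being a 1.3-fold higher number from compound 2 to compound 3 (0.13 log units; within the scatter).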

Compound 3, half-maximal inhibitory concentration: 7400 nM
Compound 3: middle estimate off by 1.2-fold (0.09 log units), on the high side; the measured number falls inside the stated range.
By their numbers in this assay, from the lowest: compounds 1, 2 and 3 (each within the scatter of the next).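

Ethyl in place of cyclohexyl on the oxygen gives (a 1.1-fold higher number from compound 2 to compound 3 (0.05 log units; within the scatter)) in this assay, and methyl in place of 4-chlorophenyl on the saturated chain carbon bound to that oxygen gives (a 1.5-fold higher number from compound 1 to compound 3 (0.16 log units; within the scatter)). The ether tail at this position can therefore shrink to ethyl, with no ring, and the number stays within the scatter of both ring-bearing compounds. Nothing at hand explains this tolerance.

The compounds shown leave open whether any tail here can move the number beyond the scatter. A terminal amine, a carboxylic acid or a longer chain on the oxygen would test this.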